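From furan-2-yl to 1-benzofuran-2-yl at the assay limit

The source may hold more compounds than are shown below. What is called first, only, known or untested is meant among the compounds shown, and "the series" means these compounds.

In a functional assay on K562 cells (Homo sapiens), read by MTT assay, with a stated time of 72 h (a lower number here means a stronger inhibitor, a higher number a weaker inhibitor), compound 1 `C#Cc1cn([C@@H]2O[C@H](CO)[C@@H](O)[C@H]2O)c2ncnc(NC)c12` gives 1380 nM. Compound 2 `Nc1nc(N)c2c(-c3ccco3)cn([C@@H]3O[C@H](CO)[C@@H](O)[C@H]3O)c2n1` reads > 20000 nM, which is a limit and not a number. This reading is the limit of > 20000 nM in this assay, at which 1 of the 2 values shown sits. Compound 3 `Nc1nc(N)c2c(-c3cc4ccccc4o3)cn([C@@H]3O[C@H](CO)[C@@H](O)[C@H]3O)c2n1` carries 1-benzofuran-2-yl in place of furan-2-yl on an aromatic carbon of the shared core: 1-benzofuran-2-yl in place of furan-2-yl on an aromatic carbon. Going by the values given here, no measured pair shows what such a change does in this assay, so any forecast starts from the reading of compound 2 at > 20000 nM. Only a small step towards stronger inhibition, hardly beyond the scatter, is expected, and compound 3 may well report only a limit too. The estimated change is an at least 1.1-fold lower number from compound 2 to compound 3 (0.04 log units; that floor lies within the scatter). For compound 3 the expected value is 18000 nM, with an estimated range from 5000 nM to 40000 nM.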

Compound 3, half-maximal inhibitory concentration: > 20000 nM
Compound 3: only a limit was reported (the forecaster's own chance of this, stated with the estimate: 65%); middle value at least 1.1-fold (0.04 log units) away from the limit.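

Compound 3 reads > 20000 nM in this assay and this is a limit, not a number. Compound 2 also reports only a limit, so no step can be read between compound 2 and compound 3. The compounds shown leave open whether furan-2-yl or 1-benzofuran-2-yl gives the stronger inhibitor.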